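Trifluoromethyl for Methyl on the Cyanophenyl Arm

The source may hold more compounds than are shown below. What is called first, only, known or untested is meant among the compounds shown, and "the series" means these compounds.

Compound 1, `CCSc1sc(-n2nc(C)c(Cc3ccccc3[N+](=O)[O-])c2C(=O)O)nc1-c1ccc(Cl)c(Cl)c1`, gives 59000 nM.
Compound 2, `Cc1cc(C#N)cc(-c2c(C)nn(-c3nc(-c4ccc(Cl)c(Cl)c4)c(SC(C)C)s3)c2C(=O)O)c1`, gives 4800 nM.
Compound 3, `Cc1c(-c2cc(Cl)cc(Cl)c2)c(C(=O)O)nn1-c1nc(-c2cc(Cl)cc(Cl)c2)c(SC(C)C)s1`, gives 2000 nM.

All three values come from a functional assay on BJAB cells (Homo sapiens) for antiproliferative activity, with a stated time of 4 days; on this read-out higher numbers stand for an effect only at larger amounts of compound and lower numbers for an effect already at smaller amounts. Among them compound 2 holds the second highest number of the three. Its nearest neighbour is compound 3, whose number is lower by a margin beyond the usual scatter, and the furthest is compound 1, whose number is higher by a margin well beyond it. Among the compounds with values here, none of these pairs differs in a single place, so no isolated step between measured compounds is available.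

Within the data shown here, compound 4, `Cc1nn(-c2nc(-c3ccc(Cl)c(Cl)c3)c(SC(C)C)s2)c(C(=O)O)c1-c1cc(C#N)cc(C(F)(F)F)c1`, is the one compound not yet measured. It differs from compound 2 in one place:

trifluoromethyl in place of methyl on an aromatic carbon

Among the measured compounds shown here, with no measured single-change step to lean on, the expectation for this exchange is a small step in this assay, likely within or only slightly beyond the scatter, in either direction. The expected step is a 1.4-fold lower number from compound 2 to compound 4 (0.14 log units; within the scatter). Compound 4 is therefore estimated at 3500 nM, with a range from 1200 nM to 10000 nM.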

Compound 4, half-maximal effective concentration: 3600 nM
For compound 4 the middle estimate is 1.0-fold (0.01 log units) below the measured one; low and high end bracket the measured number.
By their numbers in this assay, from the lowest: compounds 3, 4 and 2 (each within the scatter of the next, the first and the last beyond it); then compound 1.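

In this assay, within the data shown here, the exchange of methyl for trifluoromethyl on the cyanophenyl arm gives a 1.3-fold lower number from compound 2 to compound 4 (0.12 log units; within the scatter) and so provides the first comparison in this set that isolates a single change. The two compounds cannot be told apart on this read-out: at this aromatic carbon, meta to a cyano group, going from 1 heavy atom to 4 leaves the number within the usual scatter. No measurement at hand speaks to why the two numbers lie so close.

As far as these compounds go, whether an amine, a methoxy group or a longer chain at this position would move the number beyond the scatter remains open. Also open, from the compounds shown here alone, is how the cyano group contributes, as it is present in both compounds and is never exchanged for another group.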